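The source may report more compounds than this note shows. Statements on the series, on what has been measured and on what is new or still open speak of the compounds shown alone.

Measured so far in an assay on CHO cells for displacement of a labelled ligand from melanin-concentrating hormone receptor 1 (Homo sapiens), read by scintillation counting, with a stated time of 1 h; a higher number here means a weaker inhibitor, a lower number a stronger inhibitor:
compound 1, `Cn1c(C2CC2)nc2ccc(-n3ccc(OCc4ccc(Cl)cc4)cc3=O)cc21`, gives 35 nM
compound 2, `Cn1c(C2CC2)nc2ccc(-n3ccc(OCc4ccc(Cl)s4)cc3=O)cc21`, gives 19 nM
compound 3, `Cn1c(C2CC2)nc2ccc(-n3ccc(OCc4csc(Cl)c4)cc3=O)cc21`, gives 14 nM

Compound 3 has the lowest of the three numbers. Its nearest neighbour is compound 2, reached by a 1.4-fold lower number from compound 2 to compound 3 (0.13 log units; within the scatter), a gap too small to rank the two. Its furthest is compound 1, reached by a 2.5-fold lower number from compound 1 to compound 3 (0.40 log units; beyond the scatter).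

Compound 4, `Cn1c(C2CC2)nc2ccc(-n3ccc(OCc4cc(C(F)(F)F)cs4)cc3=O)cc21`, has not yet been measured. It differs from compound 3 in one place: 4-(trifluoromethyl)thiophen-2-yl in place of 5-chlorothiophen-3-yl on a saturated chain carbon bound to an oxygen on an aromatic ring. All three measured steps are swaps of this same aromatic group at this same place, and all were small: a 1.8-fold lower number from compound 1 to compound 2 (0.27 log units; within the scatter), a 2.5-fold lower number from compound 1 to compound 3 (0.40 log units; beyond the scatter) and a 1.4-fold lower number from compound 2 to compound 3 (0.13 log units; within the scatter). Within the data shown here, the trifluoromethyl group and its position have no measured precedent here, so the step from compound 3 to compound 4 in this assay is expected to be small, probably a somewhat higher number, with wide uncertainty. Compound 4 is estimated at 22 nM, between 8 nM and 60 nM, meaning an expected step of a 1.6-fold higher number from compound 3 to compound 4 (0.20 log units; within the scatter).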

Compound 4, half-maximal inhibitory concentration: 34 nM
The estimate for compound 4 lay 1.5-fold (0.19 log units) below the measured number, and the stated range covers the measured number.
By their numbers in this assay, from the lowest: compounds 3, 2, 4 and 1 (each within the scatter of the next, the first and the last beyond it).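

In this assay, among these compounds, a swap at this place can also cost something: a 2.4-fold higher number from compound 3 to compound 4 (0.39 log units; beyond the scatter) is a step to a higher number beyond the scatter, which no earlier step was. A thiophene ring alone does not secure the low number of compound 3: a 1.8-fold higher number from compound 2 to compound 4 (0.25 log units; within the scatter) and a 1.0-fold lower number from compound 1 to compound 4 (0.01 log units; within the scatter) both lie within the scatter, leaving compound 4 unseparated from the chlorothiophene compound 2 and the chlorophenyl compound 1. Nothing available explains the step from compound 3 to compound 4.

That step exchanges chlorine for trifluoromethyl and also changes the ring from a thiophen-3-yl to a thiophen-2-yl, and the compounds shown do not separate these two changes. Also open, as far as these compounds go, is how a thiophene carrying a nitrile or an amine would read at this place.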